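From Aminomethyl to Dichlorophenylethenyl on the Shared Core

The compounds below may be only part of what the source reports. "The series", "measured", "known", "first", "only" and "open" are said of these compounds alone.

Compound 1, `NS(=O)(=O)c1cc(-c2nnc(CN3CCN(c4ccccc4)CC3)o2)c(Cl)cc1SCc1ccccc1`: 295000 nM
Compound 2, `CCOC(=O)c1cn(Cc2nnc(-c3cc(S(N)(=O)=O)c(SCc4ccccc4)cc3Cl)o2)nn1`: 150000 nM
Compound 3, `NCc1nnc(-c2cc(S(N)(=O)=O)c(SCc3ccccc3)cc2Cl)o1`: 135000 nM

All three compounds were tested in a functional assay on MCF7 cells (Homo sapiens) for cytotoxicity, read by MTT assay, with a stated time of 72 h (on this read-out higher numbers stand for weaker inhibition and lower numbers for stronger inhibition), and all give very high numbers. Compound 3 has the lowest of the three numbers in this assay, but its neighbour compound 2 sits close to it, as a 1.1-fold lower number from compound 2 to compound 3 (0.05 log units; within the scatter) shows; only against compound 1 does compound 3 stand apart, with a 2.2-fold lower number from compound 1 to compound 3 (0.34 log units; beyond the scatter). The remaining pair, a 2.0-fold lower number from compound 1 to compound 2 (0.29 log units; within the scatter), also moves little.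

Compound 4, `NS(=O)(=O)c1cc(-c2nnc(/C=C/c3c(Cl)cccc3Cl)o2)c(Cl)cc1SCc1ccccc1`, differs from compound 3 in that (2-(2,6-dichlorophenyl)ethenyl in place of aminomethyl on an aromatic carbon). Among the compounds with values here, every measured step so far changed only what the saturated chain carbon carries, while the change to compound 4 removes that carbon and its nitrogen altogether and puts a larger unsaturated group on the five-membered ring. Within the data shown here, none of the measured steps therefore speaks directly to this change; what they do show is that varying the group on that position shifted this assay only modestly. For compound 4 the expected outcome in this assay is 100000 nM, with a range from 30000 nM to 300000 nM. The step this estimate implies, a 1.4-fold lower number from compound 3 to compound 4 (0.13 log units; within the scatter), is expected to stay small, with a wide uncertainty.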

Compound 4, half-maximal inhibitory concentration: 29000 nM
Estimate against measurement, compound 4: 3.4-fold (0.54 log units) above, outside the stated range (below it).
By their numbers in this assay, from the lowest: compound 4; then compounds 3, 2 and 1 (each within the scatter of the next, the first and the last beyond it).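

Compound 4 is the first compound shown in which the saturated chain carbon is gone from the aromatic carbon of the five-membered ring, replaced by 2-(2,6-dichlorophenyl)ethenyl, and in this assay this change gives a 4.7-fold lower number from compound 3 to compound 4 (0.67 log units; beyond the scatter). Within the data shown here, measured against the triazole-bearing group, it gives a 5.2-fold lower number from compound 2 to compound 4 (0.71 log units; beyond the scatter), so both steps lie beyond the scatter, whereas only one of the three steps among the earlier compounds did, and this position therefore responds to more than a swap of what the chain carbon carries, although compound 4 at 29000 nM still has a very high number. Nothing shown here accounts for this shift, and no measurement links it to any single feature of the entering group.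

The entering group brings a double bond, a six-membered aromatic ring and two chlorine atoms together, so the compounds shown do not separate what each part contributes. A plain phenyl on the same ethenyl group, or a saturated chain in place of the double bond, would be needed to tell these parts apart in this assay.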